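Thiazolyl in place of pyrimidinyl on the ethylated pair

A few compounds are considered here, and "the series" means these few. Any claim that something is new, unique, unknown or untested is made for them only; others in the source may bear on it.

Measured compounds:
- compound 1, `O/N=C(\CCN1CCN(c2ncccn2)CC1)c1ccccc1`, gives 39.2 nM in a functional assay on HEK293 cells with D(4) dopamine receptor (Homo sapiens) as the target, read by FLIPR; on this read-out lower numbers stand for an effect already at smaller amounts and higher numbers for an effect only at larger amounts of compound
- compound 2, `O/N=C(\CCN1CCN(c2nccs2)CC1)c1ccccc1`, gives 49.5 nM in this assay
- compound 3, `CCO/N=C(\CCN1CCN(c2ncccn2)CC1)c1ccccc1`, gives 615 nM in this assay

Compound 1 and compound 2 differ only by 1,3-thiazol-2-yl in place of pyrimidin-2-yl on an amine nitrogen in a ring. The step between them, a 1.3-fold higher number from compound 1 to compound 2 (0.10 log units; within the scatter), is within the scatter, so the two values are not told apart here.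

Compound 3 carries the core of compound 1 with ethyl in place of hydrogen on an oxygen. That change gives a 16-fold higher number from compound 1 to compound 3 (1.20 log units; beyond the scatter), a large step beyond the scatter, and compound 3 stands at the highest of the three numbers.

Compound 4, `CCO/N=C(\CCN1CCN(c2nccs2)CC1)c1ccccc1`, is not yet measured. It differs from compound 3 by 1,3-thiazol-2-yl in place of pyrimidin-2-yl on an amine nitrogen in a ring. This is the same change as from compound 1 to compound 2, at the same place, word for word; it now sits on the ethylated core of compound 3 rather than on the core of compound 1.

For this assay the expected step is a 1.3-fold higher number from compound 3 to compound 4 (0.10 log units; within the scatter), set beside the earlier one because a 1.3-fold higher number from compound 1 to compound 2 (0.10 log units; within the scatter) was within the scatter, and the same change is assumed to behave alike on the second core. Whether the ethyl on the oxygen alters that is not known from two pairs. Compound 4 is therefore estimated at 780 nM, with a range of 350 nM to 1800 nM.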

Compound 4, half-maximal effective concentration: 81.8 nM
Compound 4: the middle estimate sits 9.5-fold (0.98 log units) above what was measured; measured number outside the range, below it.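

On the ethylated core, 1,3-thiazol-2-yl in place of pyrimidin-2-yl gives a 7.5-fold lower number from compound 3 to compound 4 (0.88 log units; beyond the scatter), so in this assay this change does not carry over unaltered from the core of compound 1 to the core of compound 3: the same change on two cores in this assay, a 1.3-fold higher number (0.10 log units; within the scatter) from compound 1 to compound 2 and a 7.5-fold lower number (0.88 log units; beyond the scatter) from compound 3 to compound 4, 9.5-fold (0.98 log units) apart, beyond the scatter of two such steps. Read along the other edge of the same four compounds, ethyl in place of hydrogen on the oxygen gives a 1.7-fold higher number from compound 2 to compound 4 (0.22 log units; within the scatter) with 1,3-thiazol-2-yl on the ring nitrogen, so the large step seen with pyrimidin-2-yl does not carry over either, and the two changes do not add up independently here: the same change on two cores in this assay, a 16-fold higher number (1.20 log units; beyond the scatter) from compound 1 to compound 3 and a 1.7-fold higher number (0.22 log units; within the scatter) from compound 2 to compound 4, 9.5-fold (0.98 log units) apart, beyond the scatter of two such steps. This shows that the effect of each change depends on the other within this one set of four compounds, but it gives no cause for that dependence and no rule for other groups in either place.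

Going by these compounds, it remains open whether a methyl group or a longer chain such as propyl on the oxygen would track the ethyl result, and how steeply the read-out depends on chain length with each ring group. Also open, on these data alone, is whether a phenyl or pyridin-2-yl group on the amine nitrogen in the ring would behave like pyrimidin-2-yl or like 1,3-thiazol-2-yl once the ethyl is present.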